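A few compounds are considered here, and "the series" means these few. Any claim that something is new, unique, unknown or untested is made for them only; others in the source may bear on it.

Measured compounds:

compound 1 `COc1ccc(-c2cc(C(=O)/C=C/c3ccccc3)nc3cc(-c4ccccc4)nn23)cc1OC`: 15600 nM
compound 2 `COc1ccc(/C=C/C(=O)c2cc(-c3ccc(OC)c(OC)c3)n3nc(-c4ccccc4)cc3n2)cc1`: 14900 nM
compound 3 `COc1cc(-c2cc(C(=O)/C=C/c3ccc(Cl)cc3)nc3cc(-c4ccccc4)nn23)cc(OC)c1OC`: 19500 nM

All three were tested in a functional assay on DU-145 cells (Homo sapiens) for antiproliferative activity, read by MTT assay, with a stated time of 24 h; on this read-out higher numbers stand for weaker inhibition and lower numbers for stronger inhibition. Compound 3 lies within the scatter of both compound 1 and compound 2, so no order among the three can be claimed.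

Compound 4 `COc1ccc(-c2cc(C(=O)/C=C/c3ccc(Cl)cc3)nc3cc(-c4ccccc4)nn23)cc1OC` differs from compound 3 by hydrogen in place of methoxy on an aromatic carbon. Among the compounds with values here, only one measured step involves a methoxy group traded against hydrogen on an aromatic carbon: a 1.0-fold lower number from compound 1 to compound 2 (0.02 log units; within the scatter), which stayed within the scatter. Compound 4 also resembles compound 1, from which it differs in just one other place.

Compound 4 is therefore expected to give 17000 nM, with a range from 8000 nM to 36000 nM. The expected step, a 1.1-fold lower number from compound 3 to compound 4 (0.06 log units; within the scatter), should remain within the scatter.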

Compound 4, half-maximal inhibitory concentration: 22400 nM
Compound 4: middle estimate off by 1.3-fold (0.12 log units), on the low side; the range from low to high includes it.
By their numbers in this assay, from the lowest: compounds 2, 1, 3 and 4 (each within the scatter of the next).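

In this assay, hydrogen in place of methoxy, cutting 3,4,5-trimethoxyphenyl to 3,4-dimethoxyphenyl, gives a 1.1-fold higher number from compound 3 to compound 4 (0.06 log units; within the scatter), so this methoxy group can be removed with no readable effect. Chloro gives no readable effect either, whether it replaces methoxy, with a 1.5-fold higher number from compound 2 to compound 4 (0.18 log units; within the scatter), or hydrogen, with a 1.4-fold higher number from compound 1 to compound 4 (0.16 log units; within the scatter). The swap of methoxy and hydrogen now reads alike on two cores: the same change on two cores in this assay, a 1.0-fold lower number (0.02 log units; within the scatter) from compound 1 to compound 2 and a 1.1-fold lower number (0.06 log units; within the scatter) from compound 4 to compound 3, 1.1-fold (0.04 log units) apart, within the scatter of two such steps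

Every group shown here stays within the scatter, so nothing yet marks this position as sensitive. Going by these compounds, whether an amine or a carboxylic acid on this ring would shift the number remains open.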